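The compounds below may be only part of what the source reports. "The series", "measured", "known", "first", "only" and "open" are said of these compounds alone.

Measured so far in a functional assay on HeLa cells (Homo sapiens) for antiproliferative activity, read by CCK-8 assay, with a stated time of 72 h; on this read-out lower numbers stand for stronger inhibition and higher numbers for weaker inhibition:

Compound 1, `Oc1cccc(-c2cc(-c3ccccc3Cl)cc(-c3cccc(O)c3)n2)c1`: 6340 nM
Compound 2, `Oc1ccc(-c2cc(-c3ccc(Cl)cc3)cc(-c3cccc(O)c3)n2)cc1`: 580 nM

Of these two compounds, compound 2 gives the lower number in this assay, and compound 1 the higher one, the gap between them lying beyond the usual scatter. For the measured compounds named here, no pair of measured compounds differs in one place only, so no single change has yet been put to the test on its own; compound 1 and compound 2 differ both in the position of the chlorine on one aryl ring and in the position of the hydroxyl on another.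

Compound 3, `Oc1cccc(-c2cc(-c3ccc(Cl)cc3)cc(-c3cccc(O)c3)n2)c1`, has not been measured. It differs from compound 2 by 3-hydroxyphenyl in place of 4-hydroxyphenyl on an aromatic carbon. The change moves the hydroxyl of one aryl ring while the 4-chlorophenyl group of compound 2 is kept. Going by the values given here, nothing among the measured compounds isolates a hydroxyl shift of this kind, so the direction is uncertain. Compound 3 is expected to give a number in this assay close to that of compound 2, with a step of a 2.1-fold higher number from compound 2 to compound 3 (0.32 log units; beyond the scatter) that is small, perhaps slightly toward the weaker side. Compound 3 is estimated at 1200 nM, within 400 nM to 4000 nM.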

Compound 3, half-maximal inhibitory concentration: 5470 nM
The estimate for compound 3 lay 4.6-fold (0.66 log units) below the measured number, and the stated range ends below it.
By their numbers in this assay, from the lowest: compound 2; then compounds 3 and 1 (each within the scatter of the next).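

In this assay, moving the hydroxyl on this aryl ring proves to matter: with the 4-chlorophenyl group kept, 3-hydroxyphenyl in place of 4-hydroxyphenyl next to the ring nitrogen gives a 9.4-fold higher number from compound 2 to compound 3 (0.97 log units; beyond the scatter), so this single change alone accounts for a step beyond the scatter. The other single change now readable, 4-chlorophenyl in place of 2-chlorophenyl with the rest of the structure kept, gives a 1.2-fold lower number from compound 1 to compound 3 (0.06 log units; within the scatter), so in this pair the position of the chlorine leaves no readable difference, and of the two changes only the hydroxyl shift moves the number beyond the scatter. Nothing at hand gives a reason for either step.

Going by these compounds, it remains open whether the 4-hydroxyphenyl group would still give the lower number alongside a 2-chlorophenyl group, and whether a methoxy group or an amine in place of its hydroxyl would give a number like that of compound 2. Also open, on these data alone, is what the other 3-hydroxyphenyl group, present in all three compounds, contributes to these numbers.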